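Hydroxy on the terminal anilide of a cyclopropane bis-amide

The source may report more compounds than this note shows. Statements on the series, on what has been measured and on what is new or still open speak of the compounds shown alone.

The compounds measured so far:
compound 1, `CN(C)C(=O)c1cc2cnc(Nc3ccc(NC(=O)C4(C(=O)Nc5ccccc5)CC4)cc3)nc2n1C1CCCC1`, 52.8%;
compound 2, `Cc1ccc(NC(=O)C2(C(=O)Nc3ccc(Nc4ncc5cc(C(=O)N(C)C)n(C6CCCC6)c5n4)cc3)CC2)cc1`, 47.9%.

Both were tested in a functional assay on T47D cells (Homo sapiens) for inhibition, read by CCK-8 assay, with a stated time of 72 h, tested at 1 uM; a higher number here means more inhibition of growth at the concentration tested, a lower number less inhibition of growth. Compound 1 gives the higher of the two numbers, but the step of a number 4.9 percentage points lower from compound 1 to compound 2 (within the scatter) is within the scatter, so the two compounds cannot be told apart on these data. That step exchanged a hydrogen on an aromatic carbon for a methyl group.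

Compound 3, `CN(C)C(=O)c1cc2cnc(Nc3ccc(NC(=O)C4(C(=O)Nc5ccc(O)cc5)CC4)cc3)nc2n1C1CCCC1`, is not yet measured. It differs from compound 1 in one place: hydroxy in place of hydrogen on an aromatic carbon. For the measured compounds named here, the only measured step, the methyl substitution from compound 1 to compound 2, touched the same part of the shared core and gave no change beyond the scatter; no step with a hydroxy group has been measured, so nothing shows what this group does here. Compound 3 is therefore expected to sit close to compound 1, with the step of a number 2.8 percentage points lower from compound 1 to compound 3 (within the scatter) not beyond the scatter. The estimate for compound 3 is 50%, within 35% to 65%.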

Compound 3, percent growth inhibition at one concentration: 91.5%
Beside the measured number, compound 3's estimate is 41.5 percentage points below it, outside the stated range (above it).
By their numbers in this assay, from the lowest: compounds 2 and 1 (each within the scatter of the next); then compound 3.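

In this assay the change from phenyl to 4-hydroxyphenyl gives a number 38.7 percentage points higher from compound 1 to compound 3 (beyond the scatter) and so shows that this position, on an aromatic carbon para to a large group, is not indifferent to what it carries, something the methyl step alone gave no sign of. For the compounds shown here, with hydroxy in place of methyl at the same carbon, the result is a number 43.6 percentage points higher from compound 2 to compound 3 (beyond the scatter) while the earlier a number 4.9 percentage points lower from compound 1 to compound 2 (within the scatter) remains the only step without a clear change, so in this small set hydrogen and methyl cannot be told apart and hydroxy stands clearly apart from both. The data record the size of this rise, but nothing available here explains it.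

From the compounds shown here alone, it remains open whether a methoxy, an amine or a carboxylic acid at the same carbon would match the hydroxy, and whether a hydroxy on another carbon of that ring would do the same. Going by these compounds, because each number comes from a single concentration, it also remains open how compound 3 and compound 1 would compare across a range of concentrations.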